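From One Bromine to Two Fluorines on a Benzyl Group

A few compounds are considered here, and "the series" means these few. Any claim that something is new, unique, unknown or untested is made for them only; others in the source may bear on it.

Compound 1 `C=C1C(=O)O[C@H]2[C@H]1CC/C(Cn1cc(Cn3cc(F)c(=O)[nH]c3=O)nn1)=C\CC[C@@]1(C)O[C@@H]21` gives > 20000 nM (a limit)
Compound 2 `C=C1C(=O)O[C@H]2[C@H]1CC/C(COC(=O)Cn1cc(F)c(=O)n(Cc3ccc(Br)cc3)c1=O)=C\CC[C@@]1(C)O[C@@H]21` gives 3240 nM

In a functional assay on Bel7402/5-FU cells (Homo sapiens) for antiproliferative activity, read by MTT assay, with a stated time of 72 h (on this read-out higher numbers stand for weaker inhibition and lower numbers for stronger inhibition), compound 1 shows > 20000 nM as a limit of the assay, not a number. Going by the values given here, compound 2 at 3240 nM holds the only true number so far. Compound 3 `C=C1C(=O)O[C@H]2[C@H]1CC/C(COC(=O)Cn1cc(F)c(=O)n(Cc3ccc(F)cc3F)c1=O)=C\CC[C@@]1(C)O[C@@H]21` carries 2,4-difluorophenyl in place of 4-bromophenyl on a saturated chain carbon bound to an aromatic nitrogen and is otherwise unchanged. Among the compounds with values here, no measured pair shows such a swap, so the only anchor is compound 2 at 3240 nM and no step beyond the scatter is expected, with a slight lean toward weaker inhibition. The expected step of a 1.2-fold higher number from compound 2 to compound 3 (0.09 log units; within the scatter) is accordingly small. For compound 3 the estimate is 4000 nM with an expected range from 1500 nM to 12000 nM in this assay.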

Compound 3, half-maximal inhibitory concentration: 5010 nM
For compound 3 the middle estimate is 1.3-fold (0.10 log units) below the measured one, and the stated range covers the measured number.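

In this assay, putting 2,4-difluorophenyl in place of 4-bromophenyl on a saturated chain carbon bound to an aromatic nitrogen gives a 1.5-fold higher number from compound 2 to compound 3 (0.19 log units; within the scatter), so these two halogen patterns cannot be told apart here. Going by these compounds alone, this is the first comparison between two true numbers, and it shows that this position tolerates this swap. Nothing measured here offers a reason for the result.

Still open, as far as these compounds go, is whether a phenyl carrying an amine or a carboxylic acid, or a longer chain in place of the benzyl, would move the number beyond the scatter.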